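Coumarin-pyrazole diesters: from 4-methoxyphenyl to 3-chlorophenyl

A few compounds are considered here, and "the series" means these few. Any claim that something is new, unique, unknown or untested is made for them only; others in the source may bear on it.

Measured compounds:
compound 1, `CCOC(=O)c1c(-c2c(Cl)c3ccccc3oc2=O)nn(-c2ccccc2)c1C(=O)OCC`, 34000 nM
compound 2, `CCOC(=O)c1c(-c2c(Cl)c3ccccc3oc2=O)nn(-c2cccc(C)c2)c1C(=O)OCC`, 36000 nM
compound 3, `CCOC(=O)c1c(-c2c(Cl)c3ccccc3oc2=O)nn(-c2ccc(OC)cc2)c1C(=O)OCC`, 18000 nM

Of the compounds shown here, three with a shared core have been tested in a functional assay on A549 cells (Homo sapiens) for cytotoxicity, read by MTT assay, with a stated time of 48 h; on this read-out lower numbers stand for stronger inhibition and higher numbers for weaker inhibition. Compound 3 gives the lowest number of the three, 18000 nM, but its steps to the others are both within the scatter: a 1.9-fold lower number from compound 1 to compound 3 (0.28 log units; within the scatter) and a 2.0-fold lower number from compound 2 to compound 3 (0.30 log units; within the scatter). Compound 4, `CCOC(=O)c1c(-c2c(Cl)c3ccccc3oc2=O)nn(-c2cccc(Cl)c2)c1C(=O)OCC`, has not yet been measured. It differs from compound 3 by 3-chlorophenyl in place of 4-methoxyphenyl on an aromatic nitrogen.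

Within the data shown here, two measured steps bear on this. The substituent on the phenyl ring has so far done little: a 1.1-fold higher number from compound 1 to compound 2 (0.02 log units; within the scatter) and a 1.9-fold lower number from compound 1 to compound 3 (0.28 log units; within the scatter). Removing the methoxy group and introducing a 3-chlorophenyl in its place is therefore expected to move the number at most by a small amount, if at all, and any movement would more likely be towards the numbers of compound 1 and compound 2. Compound 4 is expected to give about 30000 nM in this assay, within a range from 15000 nM to 60000 nM, which corresponds to the estimated step of a 1.7-fold higher number from compound 3 to compound 4 (0.22 log units; within the scatter).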

Compound 4, half-maximal inhibitory concentration: 38000 nM
Beside the measured number, compound 4's estimate is 1.3-fold (0.10 log units) below it; the measured number falls inside the stated range.
By their numbers in this assay, from the lowest: compounds 3, 1, 2 and 4 (each within the scatter of the next, the first and the last beyond it).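

In this assay, among these compounds, 3-chlorophenyl in place of 4-methoxyphenyl on the aromatic nitrogen gives the first step in this set that lies beyond the scatter, though only modestly: a 2.1-fold higher number from compound 3 to compound 4 (0.32 log units; beyond the scatter). The chloro group does not separate compound 4 from the other two compounds, since a 1.1-fold higher number from compound 2 to compound 4 (0.02 log units; within the scatter) and a 1.1-fold higher number from compound 1 to compound 4 (0.05 log units; within the scatter), so this position has so far produced a difference only between the two ends of the order, compound 3 and compound 4. Nothing available explains that difference.

The compounds shown leave open whether the step goes with the methoxy group leaving, the chloro group entering, or the different place of each on the phenyl ring. They also leave open whether a phenyl ring bearing an amine or a carboxylic acid would move the number further.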